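The source may hold more compounds than are shown below. What is called first, only, known or untested is meant among the compounds shown, and "the series" means these compounds.

Measured so far:
- compound 1, `CS(=O)(=O)CCCOc1ccc2c(c1)OC(COc1ccc(CCC(=O)O)c(F)c1)CC2`, 38%
- compound 2, `O=C(O)CCc1ccc(OCC2COc3ccc(Br)cc3O2)cc1F`, 81%
- compound 3, `O=C(O)CC(c1ccc(OCC2COc3ccc(Cl)cc3O2)cc1)c1cnco1`, 63%

In a functional assay on HEK293 cells for agonist activity at Free fatty acid receptor 1 (Homo sapiens), read by fluorescence and calcium flux, with a stated time of 10 min (on this read-out higher numbers stand for larger maximal responses and lower numbers for smaller maximal responses), compound 3 stands second highest of the three numbers. Its nearest neighbour is compound 2, whose value lies higher by an amount beyond the usual scatter; the furthest is compound 1, whose value lies lower, also beyond the scatter. Compound 2 and compound 3 share the same core with a halogen on it and differ at the acid-bearing chain, so the two values show that a branched chain carrying a five-membered aromatic ring still gives a substantial maximal response, though not the level of compound 2.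

Compound 4, `O=C(O)CC(c1ccncc1)c1ccc(OCC2COc3ccc(Cl)cc3O2)cc1`, is not yet measured. It differs from compound 3 in one place: pyridin-4-yl in place of 1,3-oxazol-5-yl on a saturated chain carbon bound to an aromatic carbon and a saturated chain carbon. For the measured compounds named here, no measured pair shows what such an exchange does in this assay, so the expectation rests on compound 3 alone. A step of no more than the scatter is expected, with no clear direction, so compound 4 is estimated at 65%, within 45% to 85%, the expected step being a number 2 percentage points higher from compound 3 to compound 4 (within the scatter).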

Compound 4, largest response reached (Emax), in percent of the reference or control that the assay uses: 62%
Estimate against measurement, compound 4: 3 percentage points above; the range from low to high includes it.
By their numbers in this assay, from the lowest: compound 1; then compounds 4 and 3 (each within the scatter of the next); then compound 2.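

In this assay, pyridin-4-yl in place of 1,3-oxazol-5-yl on a saturated chain carbon bound to an aromatic carbon and a saturated chain carbon gives a number 1 percentage points lower from compound 3 to compound 4 (within the scatter). This place therefore accepts a six-membered aromatic ring with 1 hetero atom as well as a five-membered aromatic ring with 2 hetero atoms, and the two compounds read alike in maximal response, which compound 3 alone could not show. Nothing measured on these compounds bears on why the two rings read alike.

Open, from the compounds shown here alone, is whether a phenyl ring, a pyridin-3-yl ring or a simple methyl group at the same carbon would give a comparable maximal response. Also open, going by these compounds, is what a bromine in place of the chlorine on the shared core would do with either ring on the chain.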